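Ethyl on the Saturated Ring Carbon of Compound 2

This account rests on a few compounds, and the source may have more. Where it says the series, first, only, none or still open, it means among the compounds named here.

Of the compounds shown here, three sharing one core have been tested in a functional assay on NALM-6 cells (Homo sapiens) for inhibition, read by MTT assay, with a stated time of 48 h; a higher number here means a weaker inhibitor, a lower number a stronger inhibitor. Compound 1 `C=C1CN(C)N(c2ccc(Cl)cc2)C1=O` gives 51900 nM, compound 2 `C=C1CN(C)N(c2ccccc2)C1=O` gives 56000 nM, and compound 3 `C=C1CN(C)N(c2ccc(Br)cc2)C1=O` gives 62000 nM. Compound 2 cannot be separated from either of the others: a 1.1-fold higher number from compound 1 to compound 2 (0.03 log units; within the scatter) and a 1.1-fold higher number from compound 2 to compound 3 (0.04 log units; within the scatter) are both within the scatter, as is a 1.2-fold higher number from compound 1 to compound 3 (0.08 log units; within the scatter). Every one of these measured changes sits on the aromatic carbon, and none of them moves the number beyond the scatter.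

Compound 4 `C=C1C(=O)N(c2ccccc2)N(C)C1CC` differs from compound 2 at a different place: ethyl in place of hydrogen on a saturated ring carbon. Going by the values given here, no measured step touches the saturated ring carbon, so none bears directly on this change. What the measured steps do show is that the numbers in this assay have so far been nearly flat across the three compounds. With nothing pointing toward a gain or a loss, the expectation for compound 4 is a step of no size beyond the scatter. The estimated value for compound 4 in this assay is 56000 nM, with a range from 22000 nM to 140000 nM. This estimate for compound 4 corresponds to an expected step of no change at the digits printed from compound 2 to compound 4 (within the scatter).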

Compound 4, half-maximal inhibitory concentration: 576000 nM
Compound 4: the middle estimate sits 10-fold (1.01 log units) below what was measured, outside the stated range (above it).
By their numbers in this assay, from the lowest: compounds 1, 2 and 3 (each within the scatter of the next); then compound 4.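

In this assay the saturated ring carbon proves to be a place where a change registers, with ethyl in place of hydrogen giving a 10-fold higher number from compound 2 to compound 4 (1.01 log units; beyond the scatter) and so a weaker inhibitor. The earlier steps, all on the aromatic carbon, had shown no such sensitivity: hydrogen, chloro and bromo there left compound 1, compound 2 and compound 3 within the scatter of one another, so the flat numbers of that series did not extend to this position. Nothing measured here accounts for the loss, and the data offer no explanation of how this ethyl produces it.

With only hydrogen and ethyl shown on this carbon, it remains open whether the loss grows with the size of the group, or whether a methyl, a longer chain such as propyl, or a group carrying an amine or a hydroxyl would behave in the same way. Also open, on these data alone, is whether ethyl at this place would give a step of similar size with chloro or bromo on the aromatic carbon.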